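The source may report more compounds than this note shows. Statements on the series, on what has been measured and on what is new or still open speak of the compounds shown alone.

Measured compounds:
compound 1, `CCCCOc1cccc(C(=O)Nc2cccc(C(=O)O)c2)c1`, 3150 nM
compound 2, `O=C(O)c1cccc(NC(=O)c2cccc(OCC3CC3)c2)c1`, 1260 nM
compound 3, `CCCCOc1cccc(-c2cccc(C(=O)Nc3cccc(C(=O)O)c3)c2)c1`, 256 nM

All three were tested in an assay on isolated protein for agonist activity at Bile acid receptor (Homo sapiens), read by TR-FRET, with a stated time of 3 h, in the absence of a further agent; a lower number here means that less compound is needed, a higher number that more compound is needed for the effect. Compound 1 and compound 2 share one core and differ by a single change, (cyclopropyl in place of propyl on a saturated chain carbon bound to an oxygen on an aromatic ring), which gave a 2.5-fold lower number from compound 1 to compound 2 (0.40 log units; beyond the scatter). Compound 3 rests on a different core; the difference between the two cores is not broken down here. Compound 3 gives the lowest number of the three. Compound 4, `O=C(O)c1cccc(NC(=O)c2cccc(-c3cccc(OCC4CC4)c3)c2)c1`, is not yet measured. It differs from compound 3 by cyclopropyl in place of propyl on a saturated chain carbon bound to an oxygen on an aromatic ring, the same change as from compound 1 to compound 2, made at the same place. Because compound 1 to compound 2 gave a 2.5-fold lower number from compound 1 to compound 2 (0.40 log units; beyond the scatter), a step of similar size, a 2.4-fold lower number from compound 3 to compound 4 (0.39 log units; beyond the scatter), is expected for compound 4. Compound 4 is therefore estimated at 105 nM, most likely between 40 nM and 260 nM.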

Compound 4, half-maximal effective concentration: 206 nM
Compound 4: middle estimate off by 2.0-fold (0.29 log units), on the low side; the measured number falls inside the stated range.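

Moved to the second core, the swap of propyl for cyclopropyl gave a 1.2-fold lower number from compound 3 to compound 4 (0.09 log units; within the scatter). Set beside the earlier step, the two results cannot be told apart: the same change on two cores in this assay, a 2.5-fold lower number (0.40 log units; beyond the scatter) from compound 1 to compound 2 and a 1.2-fold lower number (0.09 log units; within the scatter) from compound 3 to compound 4, 2.0-fold (0.30 log units) apart, within the scatter of two such steps. This fits a change that carries from one core to the other, but it does not show that the step has the same size on both, since on the second core the step alone stays within the scatter, and two pairs say nothing about any further core.

The compounds shown leave open how cyclobutyl or a longer chain such as pentyl would behave on a saturated chain carbon bound to an oxygen on an aromatic ring. On these data alone, whether either core would respond to such groups in the same way also remains open.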